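Removing a trifluoromethyl group from a hydrazone-type binder

The source may hold more compounds than are shown below. What is called first, only, known or untested is meant among the compounds shown, and "the series" means these compounds.

Of the compounds shown here, three have been tested in an assay on isolated protein for binding affinity to corticotropin-releasing factor receptor 1 (Homo sapiens) (on this read-out higher numbers stand for weaker inhibition and lower numbers for stronger inhibition), and a fourth awaits its number. Compound 1 `CC(=O)/C(=N\c1ccccc1)NNc1ccccc1C` gives 526 nM in this assay. Compound 2 `CC(=O)/C(=N\c1cccc(C(F)(F)F)c1)NNc1ccccc1C` carries an extra trifluoromethyl group and gives 291 nM. The step from compound 2 to compound 1, (hydrogen in place of trifluoromethyl on an aromatic carbon), produced a 1.8-fold higher number from compound 2 to compound 1 (0.26 log units; within the scatter), so on this evidence the group added little either way.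

Compound 3 `CC(=O)/C(=N\c1cccc(C)c1)NNc1ccccc1C(F)(F)F` shares its atoms with compound 2 but joins them differently; the difference between the two cores is not broken down here. In this assay compound 3 gives 1420 nM, the highest of the three numbers.

Compound 4 `CC(=O)/C(=N\c1cccc(C)c1)NNc1ccccc1` is compound 3 with one change, (hydrogen in place of trifluoromethyl on an aromatic carbon). Among the compounds with values here, this is the same kind of change as the one from compound 2 to compound 1, but not the same: there the hydrogen entered meta to a large group, here it enters ortho to a large group. Within the data shown here, with only one earlier example, and that one in a different place, the expectation rests on the observation that the step from compound 2 to compound 1 was a 1.8-fold higher number from compound 2 to compound 1 (0.26 log units; within the scatter). A step of similar size is expected here, so the estimated step from compound 3 to compound 4 is a 1.5-fold higher number from compound 3 to compound 4 (0.19 log units; within the scatter). Compound 4 is therefore expected to give about 2200 nM in this assay, with an estimated range from 700 nM to 7000 nM.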

Compound 4, inhibition constant: 4710 nM
For compound 4 the middle estimate is 2.1-fold (0.33 log units) below the measured one, within the range that was stated.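

In this assay, putting hydrogen in place of trifluoromethyl on an aromatic carbon produced a 3.3-fold higher number from compound 3 to compound 4 (0.52 log units; beyond the scatter), a modest step but one larger than the usual scatter of repeated measurements. The earlier step of this kind stayed within that scatter, yet a single step beyond it does not make the two results different, since the gap between them is itself within the scatter of two such steps: the same change on two cores in this assay, a 1.8-fold higher number (0.26 log units; within the scatter) from compound 2 to compound 1 and a 3.3-fold higher number (0.52 log units; beyond the scatter) from compound 3 to compound 4, 1.8-fold (0.26 log units) apart, within the scatter of two such steps. So in this small set the change can be carried from one core to the other without a clear difference in its size, but two examples do not show that it would behave alike on further cores, and because the group leaves a different ring in each pair, these data cannot separate an effect of position from an effect of the core.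

The compounds shown leave open how a fluorine atom, a methoxy group or a nitrile in the place of the trifluoromethyl group would compare with trifluoromethyl and hydrogen. They also leave open what would happen if the methyl group on the other ring gave way to a longer chain or an amine.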